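Amide-nitrogen aryl swaps on the shared core, paw edema

A few compounds are considered here, and "the series" means these few. Any claim that something is new, unique, unknown or untested is made for them only; others in the source may bear on it.

Three compounds of the series carry the same core and differ only in the aryl group on the amide-type nitrogen. Compound 1 `O=C(Nc1ccccn1)c1c(O)c2cccnc2n(-c2ccccc2)c1=O` gives -13.5% in a functional assay on the whole organism for inhibition, with Rattus norvegicus as the target, read by paw edema, at a dose of 100 mg/kg by the oral route; on this read-out lower numbers stand for less inhibition and higher numbers for more inhibition at the one dose given (going by the name of the read-out). Compound 2 `O=C(Nc1cccc([N+](=O)[O-])c1)c1c(O)c2cccnc2n(-c2ccccc2)c1=O` gives 5.7% in this assay, and compound 3 `O=C(Nc1nccs1)c1c(O)c2cccnc2n(-c2ccccc2)c1=O` gives 4.6% in this assay. Compound 3 thus stands second highest of the three numbers, with compound 2 as its nearest neighbour and compound 1 as the furthest, the two larger steps being a number 19.2 percentage points higher from compound 1 to compound 2 (beyond the scatter) and a number 18.1 percentage points higher from compound 1 to compound 3 (beyond the scatter), while between the two six- and five-membered replacements the step is a number 1.1 percentage points lower from compound 2 to compound 3 (within the scatter).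

Compound 4 `COc1ccc(NC(=O)c2c(O)c3cccnc3n(-c3ccccc3)c2=O)cn1` is not yet measured. It differs from compound 3 in one place: 6-methoxypyridin-3-yl in place of 1,3-thiazol-2-yl on an amide-type nitrogen. For the measured compounds named here, no measured step covers a methoxy group, so the bearing steps are only the aryl swaps above. Two of them are modest and one lies within the scatter; a six-membered ring with one ring nitrogen is also present in compound 1, whose value -13.5% is the lowest. The step for compound 4 is therefore expected to be small or downward, a number 4.6 percentage points lower from compound 3 to compound 4 (within the scatter), and compound 4 is estimated at 0%, within a range from -15% to 15%.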

Compound 4, a percentage reported as inhibition, in the whole organism at one dose (the size of the read-out at that dose, not a potency): 13.1%
Estimate against measurement, compound 4: 13.1 percentage points below; the measured number falls inside the stated range.
By their numbers in this assay, from the lowest: compound 1; then compounds 3, 2 and 4 (each within the scatter of the next).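

On the amide-type nitrogen, a six-membered aromatic ring with one ring nitrogen does not by itself go with the low value of compound 1: in this assay 6-methoxypyridin-3-yl in place of pyridin-2-yl gives a number 26.6 percentage points higher from compound 1 to compound 4 (beyond the scatter) and so sets these two compounds apart. Against the other two aryl groups, the same swap gives a number 8.5 percentage points higher from compound 3 to compound 4 (within the scatter) and a number 7.4 percentage points higher from compound 2 to compound 4 (within the scatter) so compound 2, compound 3 and compound 4 all lie within the scatter of each other, with only compound 1 standing apart. The change from the five-membered ring of 1,3-thiazol-2-yl to the larger six-membered 6-methoxypyridin-3-yl therefore does not separate the two compounds on this read-out.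

Compound 4 differs from compound 1 both in the methoxy group and in how the pyridine ring is attached, so the compounds shown do not say which of the two carries the step; a plain pyridin-3-yl group, or a 6-aminopyridin-3-yl group with an amine in place of the methoxy, would bear on that. No measurement at hand speaks to the reason for any of these differences.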